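Swapping the dichlorophenoxy arm for a methoxyphenylsulfanyl arm

The source may hold more compounds than are shown below. What is called first, only, known or untested is meant among the compounds shown, and "the series" means these compounds.

Compound 1 `Nc1cc(N)c2nc(-c3ccccc3)c(Oc3ccc(Cl)c(Cl)c3)nc2c1` is one of three compounds tested in a functional assay on SK-MEL-5 cells (Homo sapiens) for inhibition, read by sulforhodamine B assay, with a stated time of 48 h; on this read-out higher numbers stand for lower toxicity in this test and lower numbers for higher toxicity in this test. In this assay compound 1 gives 83200 nM, the highest of the three numbers. Compound 2 `COc1cc(CNc2nc3cc(N)cc(N)c3nc2-c2ccccc2)cc(OC)c1OC` gives 29500 nM and compound 3 `COc1ccc(CNc2nc3cc(N)cc(N)c3nc2-c2ccccc2)cc1OC` gives 77600 nM; the gap from compound 1 to compound 3 is within the scatter, whereas the gap to compound 2 is beyond it. Within the data shown here, the one measured step, a 2.6-fold higher number from compound 2 to compound 3 (0.42 log units; beyond the scatter), shows that removing a methoxy from the side arm shifts the number modestly.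

Compound 4 `COc1ccc(Sc2nc3cc(N)cc(N)c3nc2-c2ccccc2)cc1` differs from compound 1 by (4-methoxyphenyl)sulfanyl in place of 3,4-dichlorophenoxy on an aromatic carbon. Among the measured compounds shown here, no measured pair compares an ether with a thioether or chlorines with a methoxy on this arm, so the single step from compound 2 to compound 3 bears on it only loosely. The author therefore expects compound 4 to stay close to compound 1, with the step of a 1.5-fold lower number from compound 1 to compound 4 (0.18 log units; within the scatter) small, and estimates for compound 4 a value of 55000 nM, within a range from 15000 nM to 150000 nM.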

Compound 4, concentration lethal to 50% of the cells: < 100000 nM
Compound 4: no number, only a limit (the forecaster's own chance of this, stated with the estimate: 10%); the middle value lies beyond the limit too.
By their numbers in this assay, from the lowest: compound 2; then compounds 3 and 1 (each within the scatter of the next).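

In this assay compound 4 gives < 100000 nM, which is a limit and not a number. The step from compound 1 to compound 4 cannot be read. The compounds shown leave open whether (4-methoxyphenyl)sulfanyl in place of 3,4-dichlorophenoxy changes the number at all, and in which direction.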